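Notes on benzylating the amino nitrogen of compound 2

A few compounds are considered here, and "the series" means these few. Any claim that something is new, unique, unknown or untested is made for them only; others in the source may bear on it.

Compound 1 `CC(=O)Nc1cc(OCc2ccccc2)nc(SCc2ccccc2)n1`: 35200 nM in a functional assay on A549 cells (Homo sapiens) for antiproliferative activity, read by MTT assay, with a stated time of 72 h; on this read-out lower numbers stand for stronger inhibition of growth and higher numbers for weaker inhibition of growth
Compound 2 `COc1cc(OC)n2cc(-c3ccc(N)cc3)nc2n1`: > 100000 nM in this assay

Compound 2 reports only (the limit of > 100000 nM in this assay, at which 1 of the 2 values shown sits), so it stands at the weak end of the numbers shown. Compound 3 `COc1cc(OC)n2cc(-c3ccc(NCc4ccccc4)cc3)nc2n1` differs from compound 2 by benzyl in place of hydrogen on a nitrogen on an aromatic ring. Going by the values given here, no measured pair carries this change, so the step in this assay is not known; compound 1 and compound 2 differ in several places, and their two values show only that one gives a number and the other a limit. A modest step toward stronger inhibition is expected, an at least 1.6-fold lower number from compound 2 to compound 3 (0.22 log units; that floor lies within the scatter). Compound 3 is estimated at 60000 nM, between 15000 nM and 250000 nM.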

Compound 3, concentration for 50% growth inhibition: > 100000 nM
Compound 3 ended at the assay's limit (the forecaster's own chance of this, stated with the estimate: 45%); middle value at least 1.6-fold (0.22 log units) away from the limit.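

Going by these compounds alone, compound 2 and compound 3 both end at a limit of the assay, not at a number, so no step between them can be read: the limit of > 100000 nM in this assay, at which 2 of the 3 values shown sit. As far as these compounds go, whether benzyl in place of hydrogen on a nitrogen on an aromatic ring changes growth inhibition at all stays open.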